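Chain lengthening of a fluorinated isothiocyanate amide

A few compounds are considered here, and "the series" means these few. Any claim that something is new, unique, unknown or untested is made for them only; others in the source may bear on it.

Measured compounds:
compound 1 `CN(C)C(=O)c1cc2cnc(Nc3ccc(C(=O)NCCCCCN=C=S)cc3)nc2n1C1CCCC1`, 100%
compound 2 `CN(C)C(=O)c1cc2cnc(Nc3ccc(C(=O)NCCCCN=C=S)cc3F)nc2n1C1CCCC1`, 24.4%

In a functional assay on A549 cells (Homo sapiens) for inhibition, read by CCK-8 assay, with a stated time of 72 h, tested at 10 uM (a higher number here means a stronger effect of the compound at the concentration tested, a lower number a weaker effect), compound 1 gives 100%, and compound 2 gives 24.4%. Compound 2 thus stands lowest of the two numbers, its nearest neighbour being compound 1, whose value lies well beyond the scatter above it. Compound 1 and compound 2 differ in two places at once, so the two values alone do not tell which part of the change carries the drop.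

Compound 3 `CN(C)C(=O)c1cc2cnc(Nc3ccc(C(=O)NCCCCCN=C=S)cc3F)nc2n1C1CCCC1` has not yet been measured. Compared with compound 2, the change is a group of 4 heavy atoms (2 carbon, 1 nitrogen, 1 sulfur; no ring) in place of a group of 3 heavy atoms (1 carbon, 1 nitrogen, 1 sulfur; no ring), on a saturated chain carbon, four bonds along the chain from an amide-type nitrogen. Compound 3 therefore shares its chain length with compound 1 and its fluorine with compound 2. Among the measured compounds shown here, no single-change step is known for this assay, so the expectation rests on the spread between compound 1 and compound 2. Compound 3 is expected to rise from compound 2 by a number 30.6 percentage points higher from compound 2 to compound 3 (beyond the scatter), toward but not necessarily reaching compound 1. In this assay compound 3 is estimated at 55%, within a wide range from 15% to 100%.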

Compound 3, a percentage reported as inhibition, at one concentration (the size of the read-out at that concentration, not a potency): 15.6%
For compound 3 the middle estimate is 39.4 percentage points above the measured one; measured number inside the range.
By their numbers in this assay, from the lowest: compounds 3 and 2 (each within the scatter of the next); then compound 1.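

With the chain held the same, fluoro in place of hydrogen on an aromatic carbon now stands alone as a single change, and in this assay it gives a step of a number 84.4 percentage points lower from compound 1 to compound 3 (beyond the scatter), so this one substitution is enough to produce a large loss of inhibition. At the chain position, four bonds along from an amide-type nitrogen, the group of 4 heavy atoms in place of the group of 3 gives a number 8.8 percentage points lower from compound 2 to compound 3 (within the scatter), so with the fluoro present, this change of chain does not separate the two compounds. No measurement on hand explains why the fluoro step is so large.

The compounds shown leave open whether the chain change would also make no clear difference without the fluoro, since the partner of compound 1 with the shorter chain and hydrogen on the aromatic carbon is absent from this set. They also leave open whether a chloro or methoxy group on that aromatic carbon, or a still longer chain ending in the isothiocyanate, would keep the inhibition or lose it.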